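A few compounds are considered here, and "the series" means these few. Any claim that something is new, unique, unknown or untested is made for them only; others in the source may bear on it.

Measured so far:
compound 1 `CC(C)c1onc(-c2c(Cl)cccc2Cl)c1COc1ccc(-c2nc3ccc(C(=O)O)cc3n2CC2CCCCC2)c(F)c1` gives 7.8 nM in an assay on Huh-7 cells for agonist activity at Bile acid receptor (Homo sapiens), read by a luciferase reporter; a higher number here means that more compound is needed for the effect, a lower number that less compound is needed
compound 2 `CC(C)c1onc(-c2c(Cl)cccc2Cl)c1COc1ccc(-c2nc3ccc(C(=O)O)cc3n2C)c(Cl)c1` gives 3.66 nM in this assay

Compound 2 stands lowest of the two numbers; compound 1 sits beyond the scatter above it. Compound 3 `CC(C)c1onc(-c2c(Cl)cccc2Cl)c1COc1ccc(-c2nc3ccc(C(=O)O)cc3n2CC2CCCCC2)c(Cl)c1` is not yet measured. It differs from compound 2 by cyclohexyl in place of hydrogen on a saturated chain carbon bound to an aromatic nitrogen. Among the compounds with values here, no pair of measured compounds isolates this change; compound 1 carries the same cyclohexylmethyl group but differs from compound 2 elsewhere too, so its value is not a clean guide. The expected step is small, most likely none beyond the scatter: a 1.4-fold higher number from compound 2 to compound 3 (0.14 log units; within the scatter). Compound 3 is therefore expected at 5 nM, within 1.5 nM to 15 nM.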

Compound 3, half-maximal effective concentration: 7.6 nM
For compound 3 the middle estimate is 1.5-fold (0.18 log units) below the measured one; the range from low to high includes it.
By their numbers in this assay, from the lowest: compound 2; then compounds 3 and 1 (each within the scatter of the next).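

In this assay, methyl to cyclohexylmethyl on a saturated chain carbon bound to an aromatic nitrogen now reads as a single change: a 2.1-fold higher number from compound 2 to compound 3 (0.32 log units; beyond the scatter) is a modest step, and the larger group is not lost from the series. With cyclohexylmethyl in place, chloro in place of fluoro on an aromatic carbon gives a 1.0-fold lower number from compound 1 to compound 3 (0.01 log units; within the scatter) and so shows no change beyond the scatter. No measured evidence here bears on the reason for either step.

From the compounds shown here alone, whether a butyl chain or a piperidinylmethyl group at this place stays nearer to compound 2 remains open. So does the chloro and fluoro exchange with methyl in place of cyclohexylmethyl.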